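Cytotoxicity notes: nitrile analogue of the tricyclic acid

The compounds below may be only part of what the source reports. "The series", "measured", "known", "first", "only" and "open" are said of these compounds alone.

Measured so far in an ADME assay (Gallus gallus) for cytotoxicity, read by microscopy, with a stated time of 24 h; on this read-out lower numbers stand for higher toxicity in this test and higher numbers for lower toxicity in this test:
- compound 1 `O=C(O)C12CCCC3CC(CCC31)C2`: 10000000 nM
- compound 2 `CCCCNC(=O)C12CCCC3CC(CCC31)C2`: 300000 nM

Compound 1 stands at the highest of the two numbers in this assay; its nearest neighbour is compound 2, and the step of a 33-fold lower number from compound 1 to compound 2 (1.52 log units; beyond the scatter) is large and beyond the scatter. Among the measured compounds shown here, that step is the replacement of hydroxy by butylamino on a carbonyl carbon, the only measured change on the shared core of compound 1.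

Compound 3 `N#CC12CCCC3CC(CCC31)C2` is not yet measured. The change cyano in place of carboxy on a saturated ring carbon removes the same carboxy group that was altered in the step to compound 2, though here the whole group leaves and a smaller group enters.

For the measured compounds named here, the one measured step bearing on it, from compound 1 to compound 2, was large and lowered the number. Compound 3 is therefore expected to give a lower number than compound 1 as well, with the step of a 6.7-fold lower number from compound 1 to compound 3 (0.82 log units; beyond the scatter) estimated to be smaller than that to compound 2, since the change differs in kind. For compound 3 the estimate in this assay is 1500000 nM, with a range from 300000 nM to 10000000 nM.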

Compound 3, minimum cytotoxic concentration: 850000 nM
Estimate against measurement, compound 3: 1.8-fold (0.25 log units) above; measured number inside the range.
By their numbers in this assay, from the lowest: compound 2; then compound 3; then compound 1.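

In this assay, the change at this saturated ring carbon gives a 12-fold lower number from compound 1 to compound 3 (1.07 log units; beyond the scatter), so the number also falls when the whole carboxy group leaves, not only when hydroxy on the carbonyl carbon is replaced, as in a 33-fold lower number from compound 1 to compound 2 (1.52 log units; beyond the scatter). Cyano has 2 heavy atoms against 3 in carboxy, so the fall at this position does not require a longer chain such as butylamino, and among the three compounds shown the highest number stays with the carboxy group of compound 1. No measurement at hand accounts for either fall.

Still open, on these data alone, is whether the high number belongs to the carboxylic acid alone or would survive in close relatives on the same carbon, such as a methyl ester, an unsubstituted amide or a hydroxymethyl group, and whether an amine there would fall as far. Also open, as far as these compounds go, is whether butylamino and cyano act alike by chance, which a shorter amide chain such as methylamino would begin to test.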